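Hydroxy in Place of Hydrogen: Expected Maximal Response

A few compounds are considered here, and "the series" means these few. Any claim that something is new, unique, unknown or untested is made for them only; others in the source may bear on it.

Measured so far:
Compound 1 `CCCOc1ccc(-c2nc3cc(C(F)(F)F)ccc3[nH]2)cc1`: in a functional assay on aorta (Rattus norvegicus, strain Wistar) for inhibition, with a stated time of 60 min (on this read-out higher numbers stand for larger maximal responses and lower numbers for smaller maximal responses), compound 1 gives 19%.
Compound 2 `FC(F)(F)c1ccc2[nH]c(-c3ccccc3)nc2c1`: in this assay compound 2 gives 75.6%.

Compound 2 stands highest of the two measured compounds; its nearest neighbour is compound 1, and the step of a number 56.6 percentage points higher from compound 1 to compound 2 (beyond the scatter) separates them. Compound 3 `Oc1ccc(-c2nc3cc(C(F)(F)F)ccc3[nH]2)cc1` has not yet been measured in this assay. It differs from compound 2 in one place: hydroxy in place of hydrogen on an aromatic carbon. Among the compounds with values here, the only measured step that bears on this change is a number 56.6 percentage points higher from compound 1 to compound 2 (beyond the scatter), in which a propoxy group left the same aromatic carbon and the maximal response rose sharply. Placing a hydroxy group there is therefore expected to lower the maximal response, since a single step cannot say how far. A step of intermediate size is expected, a number 30.6 percentage points lower from compound 2 to compound 3 (beyond the scatter). Compound 3 is thus estimated at 45%, with a range from 20% to 75%.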

Compound 3, largest response reached (Emax), in percent of the reference or control that the assay uses: 37%
The estimate for compound 3 lay 8 percentage points above the measured number, and the stated range covers the measured number.
By their numbers in this assay, from the lowest: compound 1; then compound 3; then compound 2.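

Hydroxy on this aromatic carbon gives a number 38.6 percentage points lower from compound 2 to compound 3 (beyond the scatter) in this assay, so the maximal response falls with this single oxygen-bearing group as well as with propoxy. Taking the propyl off that oxygen gives only a number 18 percentage points higher from compound 1 to compound 3 (beyond the scatter) and recovers a smaller part of the response, which places most of the drop with hydroxy alone and a further, smaller drop with the propyl chain. Nothing available explains why the maximal response shifts in this way.

The compounds shown leave open whether an oxygen on this carbon is needed for the drop, which a methyl or chlorine group there could test. They also leave open how an amine, a carboxylic acid or a longer chain than propoxy would place the maximal response.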